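Lengthening the Carbamate Chain of Compound 1

A few compounds are considered here, and "the series" means these few. Any claim that something is new, unique, unknown or untested is made for them only; others in the source may bear on it.

Of the compounds shown here, three have so far been measured in a functional assay on HT-29 cells (Homo sapiens) for cytotoxicity, read by MTT assay, with a stated time of 72 h; on this read-out lower numbers stand for stronger inhibition of growth and higher numbers for weaker inhibition of growth. Compound 1 `CCOC(=O)Nc1ccc([Se]C#N)cc1` gives 9300 nM in this assay. Compound 2 `O=C(Nc1ccc([Se][Se]c2ccc(NC(=O)Oc3ccccc3)cc2)cc1)Oc1ccccc1` gives 13000 nM, and compound 3 `O=C(Nc1ccc([Se][Se]c2ccc(NC(=O)Oc3ccc(F)cc3)cc2)cc1)Oc1ccc(F)cc1` gives 18500 nM. Compound 1 carries the lowest of the three numbers, yet its distance to compound 2 and to compound 3 lies within the scatter of repeated measurements, so the three compounds are not separated in this assay.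

Compound 4 `CCCCOC(=O)Nc1ccc([Se]C#N)cc1` has not been measured. It differs from compound 1 in one place: ethyl in place of hydrogen on a saturated chain carbon, two bonds along the chain from an oxygen next to a carbonyl group. The carbamate ester thus grows from ethoxy to butoxy while the rest of the molecule stays the same.

Going by the values given here, no measured pair shows what such a lengthening does in this assay, so a small step is expected. The step of a 1.1-fold lower number from compound 1 to compound 4 (0.04 log units; within the scatter) is expected to stay within the scatter, with no clear direction. Compound 4 is therefore expected to give about 8500 nM in this assay, within a range from 3000 nM to 25000 nM.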

Compound 4, concentration for 50% growth inhibition in the HT-29 assay: 8100 nM
Compound 4: the middle estimate sits 1.0-fold (0.02 log units) above what was measured, within the range that was stated.
By their numbers in the HT-29 assay, from the lowest: compounds 4, 1, 2 and 3 (each within the scatter of the next, the first and the last beyond it).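

In the HT-29 assay, lengthening ethoxy to butoxy gives a 1.1-fold lower number from compound 1 to compound 4 (0.06 log units; within the scatter), so this position accepts the longer chain without a clear gain or loss in growth inhibition. In a physicochemical assay, with a stated time of 6 min, tested at 0.1 mg/mL (on this read-out lower numbers stand for less inhibition and higher numbers for more inhibition at the one concentration tested (going by the name of the read-out)), compound 1 gives 26.3% and compound 4 gives 12.6%, which makes a number 13.7 percentage points lower from compound 1 to compound 4 (beyond the scatter). The earlier compounds shown here offered no measured step of this kind, and this pair now shows that a single change at this position can leave one read-out within the scatter while moving another beyond it.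

Two chain lengths cannot show whether the percentage keeps falling as the chain grows or whether growth inhibition stays level with further lengthening. A propoxy or hexyloxy group, or a chain ending in an amine, would show how far either result extends.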